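The source may hold more compounds than are shown below. What is called first, only, known or untested is meant among the compounds shown, and "the series" means these compounds.

Working notes on the series. The common core carries a saturated chain on one amide-type nitrogen and an aroyl group on the other. In a functional assay on MCF7 cells (Homo sapiens) for cytotoxicity, read by MTT assay, with a stated time of 48 h (on this read-out lower numbers stand for stronger inhibition and higher numbers for weaker inhibition), compound 1 `CCCCCCCCNC(=O)[C@@H](NC(=O)c1ccccc1)[C@@H](C)O` gives 111000 nM; compound 2 `CCCCCCCCNC(=O)[C@@H](NC(=O)c1cc2ccccc2o1)[C@@H](C)O` gives 47200 nM, the change being a 2.4-fold lower number from compound 1 to compound 2 (0.37 log units; beyond the scatter). Compound 3 `CCCCCCCCCCCCNC(=O)[C@@H](NC(=O)c1cc2ccccc2o1)[C@@H](C)O` gives 20900 nM, the change from compound 2 being a 2.3-fold lower number from compound 2 to compound 3 (0.35 log units; beyond the scatter). Compound 3 thus stands lowest of the three numbers, with compound 2 nearest and compound 1 furthest.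

Compound 4 `CCCCCCCCCCCCNC(=O)[C@@H](NC(=O)/C=C/c1ccccc1)[C@@H](C)O` differs from compound 3 by 2-phenylethenyl in place of 1-benzofuran-2-yl on a carbonyl carbon. Among the compounds with values here, the only step that touches the group on this carbonyl carbon is a 2.4-fold lower number from compound 1 to compound 2 (0.37 log units; beyond the scatter), where the benzofuran-2-yl lowered the number relative to phenyl; no measured step shows the 2-phenylethenyl group, so its effect is unknown. Within the data shown here, since the only relevant step is a 2.4-fold lower number from compound 1 to compound 2 (0.37 log units; beyond the scatter) and it was modest, a modest rise in this assay is expected for compound 4, of about a 1.5-fold higher number from compound 3 to compound 4 (0.19 log units; within the scatter). Compound 4 is therefore estimated at 32000 nM, within a range of 12000 nM to 85000 nM.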

Compound 4, half-maximal inhibitory concentration: > 200000 nM
Compound 4: no number, only a limit; the forecaster's own chance of this, stated with the estimate: 5%; at least 6.2-fold (0.79 log units) between middle value and limit.
By their numbers in this assay, from the lowest: compound 3; then compound 2; then compound 1. At a limit, above all of these: compound 4.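

In this assay compound 4 has no number, only a limit: the limit of > 200000 nM in this assay, at which 1 of the 4 values shown sits.

The group on the carbonyl carbon can move the read-out much further than the modest 2.4-fold lower number from compound 1 to compound 2 (0.37 log units; beyond the scatter) suggested, since replacing 1-benzofuran-2-yl with 2-phenylethenyl gives an at least 9.5-fold higher number from compound 3 to compound 4 (0.98 log units; beyond the scatter). The chain shared by compound 3 and compound 4 therefore does not hold the number low once 1-benzofuran-2-yl leaves. This single change removes a five-membered aromatic ring with 1 hetero atom and a hydrogen-bond acceptor and brings in a double bond outside aromatic rings, and the step cannot separate these features.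

Going by these compounds, whether the same step holds with the shorter chain of compound 2 remains open. Also open, on these data alone, is how a 2-phenylethyl group, or a 1-benzofuran-2-yl group carrying an amine, would read on this carbonyl carbon.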